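The source may hold more compounds than are shown below. What is called first, only, known or untested is meant among the compounds shown, and "the series" means these compounds.

In a functional assay on HEK293 cells for agonist activity at Glucose-dependent insulinotropic receptor (Homo sapiens), read by reporter gene assay and cAMP accumulation, with a stated time of 6 h (on this read-out lower numbers stand for an effect already at smaller amounts and higher numbers for an effect only at larger amounts of compound), compound 1 `NC(=O)CC1CCN(c2nc(-c3cc(F)c(Cl)cc3F)nc3c2CS(=O)(=O)C3)CC1` gives 8.3 nM. Within the data shown here, compound 2 `NC(=O)CN1CCN(c2nc(-c3cc(F)c(Cl)cc3F)nc3c2CS(=O)(=O)C3)CC1` gives 44 nM in this assay, the higher of the two numbers recorded so far, the only measured step being a 5.3-fold higher number from compound 1 to compound 2 (0.72 log units; beyond the scatter). Compound 3 `CNC(=O)C1CCN(c2nc(-c3cc(F)c(Cl)cc3F)nc3c2CS(=O)(=O)C3)CC1` differs from compound 2 by 4-(methylcarbamoyl)piperidin-1-yl in place of 4-(carbamoylmethyl)piperazin-1-yl on an aromatic carbon. Among the measured compounds shown here, that change brings back a piperidine ring as in compound 1 but also alters the amide fragment, and no measured pair tests that second part. Compound 3 is therefore expected to give a lower number, with an expected step of a 2.9-fold lower number from compound 2 to compound 3 (0.47 log units; beyond the scatter) and an estimate of 15 nM ranging from 4 nM to 60 nM.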

Compound 3, effective concentration (reported as EC, without a stated level of effect): 51 nM
The estimate for compound 3 lay 3.4-fold (0.53 log units) below the measured number, and the stated range covers the measured number.
By their numbers in this assay, from the lowest: compound 1; then compounds 2 and 3 (each within the scatter of the next).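

In this assay a piperidine ring alone does not recover the number of compound 1: 4-(methylcarbamoyl)piperidin-1-yl in place of 4-(carbamoylmethyl)piperazin-1-yl gives a 1.2-fold higher number from compound 2 to compound 3 (0.06 log units; within the scatter) and leaves the two compounds indistinguishable. With the piperidine ring kept, methylcarbamoyl in place of carbamoylmethyl on a saturated ring carbon gives a 6.1-fold higher number from compound 1 to compound 3 (0.79 log units; beyond the scatter) and so shows that this amide change alone moves the number beyond the scatter. Nothing available here explains either step.

Going by these compounds, whether a longer chain between ring and amide would hold the number of compound 1 remains open. So does the effect of a carboxylic acid in place of the amide.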